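From a Limit to an Estimate for Compound 3

A few compounds are considered here, and "the series" means these few. Any claim that something is new, unique, unknown or untested is made for them only; others in the source may bear on it.

Compound 1 `O=C([C@H]1CC2CCC1C2)N1CC(c2nc(-c3ccccc3)no2)C1`: 120 nM
Compound 2 `O=C(C1CCC1)N1CC(c2nc(-c3cccc(Cl)c3)no2)C1`: > 10000 nM

Of the compounds shown here, two have been measured in an assay on HEK293 cells for positive allosteric modulation of metabotropic glutamate receptor 5 (Homo sapiens), read by FLIPR; a higher number here means that more compound is needed for the effect, a lower number that less compound is needed. Compound 1 gives 120 nM. Compound 2 reaches only a limit of the assay, > 10000 nM, so no number is known for it (the limit of > 10000 nM in this assay, at which 1 of the 2 values shown sits). Among the measured compounds shown here, compound 2 therefore sits at the weak end of what this assay can report, and no step between it and compound 1 is counted, since the two differ in more than one place.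

Compound 3 `CC1CN(C(=O)N2CC(c3nc(-c4cccc(Cl)c4)no3)C2)CC(C)O1` is not yet measured. It differs from compound 2 in one place: 2,6-dimethylmorpholin-4-yl in place of cyclobutyl on a carbonyl carbon. For the measured compounds named here, no measured step of this kind exists here, so the size of the change in this assay cannot be read from the data. Because compound 2 stands at the limit (the limit of > 10000 nM in this assay, at which 1 of the 2 values shown sits), any movement can only be toward a smaller number or none at all.

Compound 3 is expected to give an estimate of 4000 nM, with a range from 800 nM to 10000 nM. That estimate implies an expected step of an at least 2.5-fold lower number from compound 2 to compound 3 (0.39 log units; beyond the scatter), a guarded expectation, since the assay may again report only a limit.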

Compound 3, half-maximal effective concentration: > 10000 nM
Compound 3 was reported as a limit; the forecaster's own chance of this, stated with the estimate: 50%; middle value at least 2.5-fold (0.39 log units) away from the limit.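

In this assay, compound 3 gives > 10000 nM, which is a limit of the assay and not a number. Among the compounds shown here, compound 2 also stands at a limit, so no step from compound 2 to compound 3 can be read: the limit of > 10000 nM in this assay, at which 2 of the 3 values shown sit. The compounds shown leave open whether 2,6-dimethylmorpholin-4-yl in place of cyclobutyl on a carbonyl carbon changes the value at all.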